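Replacing the aromatic-nitrogen substituent of compound 2

The source may report more compounds than this note shows. Statements on the series, on what has been measured and on what is new or still open speak of the compounds shown alone.

Measured in a functional assay on NCI-H2286 cells (Homo sapiens) for antiproliferative activity, read by CCK-8 assay, with a stated time of 72 h; on this read-out lower numbers stand for stronger inhibition and higher numbers for weaker inhibition:
Compound 1 `CCn1cc(-c2n[nH]c3cc(-c4cc(C(=O)Nc5cccc(C(F)(F)F)c5)ccc4C)ccc23)cn1` gives 19.8 nM
Compound 2 `Cc1ccc(C(=O)Nc2cccc(C(F)(F)F)c2)cc1-c1ccc2c(-c3cnn(CC(=O)N(C)C)c3)n[nH]c2c1` gives > 1000 nM

For compound 2, > 1000 nM is a limit and not a number. Compound 3 `Cc1ccc(C(=O)Nc2cccc(C(F)(F)F)c2)cc1-c1ccc2c(-c3cnn(C4CCOC4)c3)n[nH]c2c1` differs from compound 2 by oxolan-3-yl in place of (dimethylcarbamoyl)methyl on an aromatic nitrogen and has oxolan-3-yl in place of (dimethylcarbamoyl)methyl on an aromatic nitrogen. For the measured compounds named here, the one measured step that bears on this is large: an at least 50-fold higher number from compound 1 to compound 2 (1.70 log units; beyond the scatter). Compound 3 has no dimethylcarbamoyl group, and neither has compound 1 at 19.8 nM, so a large move to a lower number is expected. The expected change is an at least 14-fold lower number from compound 2 to compound 3 (1.15 log units; beyond the scatter) in this assay. For compound 3 the estimate is 70 nM (expected range 15 nM to 350 nM).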

Compound 3, half-maximal inhibitory concentration: 69.7 nM
For compound 3 the middle estimate is 1.0-fold (0.00 log units) above the measured one, within the range that was stated.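

In this assay, the aromatic nitrogen accepts a saturated ring with activity retained, with an at least 14-fold lower number from compound 2 to compound 3 (1.15 log units; beyond the scatter). The figure for compound 2 is a limit and not a number: the limit of > 1000 nM in this assay, at which 1 of the 3 values shown sits.

Oxolan-3-yl does not match ethyl, with a 3.5-fold higher number from compound 1 to compound 3 (0.55 log units; beyond the scatter), so this position separates even these two smaller groups, not only (dimethylcarbamoyl)methyl from the rest.

Whether the ring oxygen or the ring itself accounts for the step from ethyl stays open, and a cyclopentyl group would separate the two. Going by these compounds, how a piperidin-4-yl ring, with its amine, or a longer alkyl chain would rank at this nitrogen also remains open.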